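The source may report more compounds than this note shows. Statements on the series, on what has been measured and on what is new or still open speak of the compounds shown alone.

Compound 1 `Cc1noc(C)c1-c1cnc(N)c(Oc2ccc(C(=O)Nc3ccc(Cl)cn3)cc2)n1` gives 35600 nM in a functional assay on HepG2 cells (Homo sapiens) for inhibition, read by MTT assay, with a stated time of 72 h; on this read-out lower numbers stand for stronger inhibition and higher numbers for weaker inhibition.
Compound 2 `Cn1cc(-c2cnc(N)c(Oc3ccc(C(=O)Nc4ccccc4Cl)cc3)n2)cn1` gives 66900 nM in this assay.
Compound 3 `Cn1cc(-c2cnc(N)c(Oc3ccc(C(=O)Nc4ccc(Cl)cc4)cc3)n2)cn1` gives 11900 nM in this assay.

Compound 3 has the lowest of the three numbers: compound 1 lies nearest with a number three-ish times higher, beyond the scatter, and compound 2 furthest. The one step among these, a 5.6-fold lower number from compound 2 to compound 3 (0.75 log units; beyond the scatter), concerns only where the chlorine sits on the amide-bearing ring.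

Compound 4 `Cn1cc(-c2cnc(N)c(Oc3ccc(C(=O)Nc4ccc(Cl)cn4)cc3)n2)cn1` is not yet measured in this assay. It differs from compound 3 by 5-chloropyridin-2-yl in place of 4-chlorophenyl on an amide-type nitrogen. Among the compounds with values here, no measured step covers this exchange directly. Compound 1 carries the same 5-chloropyridin-2-yl amide but a different group on the shared core, so its relation to compound 3 is confounded; the two values show compound 1 at 35600 nM against compound 3 at 11900 nM, a higher number with the pyridinyl. Taken as a weak hint, a modest rise is expected, within or just beyond the scatter.

Compound 4 is therefore estimated at 22000 nM, with a range from 8000 nM to 60000 nM. This expected step, a 1.8-fold higher number from compound 3 to compound 4 (0.27 log units; within the scatter), is small and uncertain.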

Compound 4, half-maximal inhibitory concentration: 24200 nM
Compound 4: middle estimate off by 1.1-fold (0.04 log units), on the low side; the measured number falls inside the stated range.
By their numbers in this assay, from the lowest: compound 3; then compounds 4, 1 and 2 (each within the scatter of the next, the first and the last beyond it).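

In this assay, the exchange of 4-chlorophenyl for 5-chloropyridin-2-yl on the amide-type nitrogen can now be read directly with the rest of the molecule held constant, and it gives a 2.0-fold higher number from compound 3 to compound 4 (0.31 log units; beyond the scatter), a modest step only just beyond the scatter. The same group also stands against 2-chlorophenyl, with a 2.8-fold lower number from compound 2 to compound 4 (0.44 log units; beyond the scatter), so among these three amide groups on the shared core, 5-chloropyridin-2-yl falls between the two chlorophenyl isomers, with each step beyond the scatter. The second single change, 1-methyl-1H-pyrazol-4-yl in place of 3,5-dimethyl-1,2-oxazol-4-yl on an aromatic carbon, gives a 1.5-fold lower number from compound 1 to compound 4 (0.17 log units; within the scatter), which lies within the scatter, so with the 5-chloropyridin-2-yl amide in place, these two groups are not told apart in this assay.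

Nothing available gives a reason for these steps. The compounds shown leave open whether the chlorine itself matters, since every amide group here carries one and none has a methyl, a methoxy or a plain hydrogen at that place, and whether the 4-chlorophenyl amide would keep its standing alongside 3,5-dimethyl-1,2-oxazol-4-yl.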